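The source may hold more compounds than are shown below. What is called first, only, known or untested is meant among the compounds shown, and "the series" means these compounds.

In a functional assay on the whole organism for inhibition, with Nicotiana tabacum as the target (on this read-out lower numbers stand for stronger inhibition and higher numbers for weaker inhibition), compound 1 `Cc1nc(Nc2ccccc2)c2cc[nH]c2n1` gives 550000000 nM, compound 3 `Cc1nc(Nc2ccc(N)cc2)c2cc[nH]c2n1` gives 195000000 nM, and compound 2 `Cc1ccc(Nc2[nH]c(C)nc3nccc2-3)cc1` gives 759000000 nM, the highest of the three numbers, with compound 1 within the scatter of it and compound 3 beyond it. Compound 4 `CCOc1ccc(Nc2[nH]c(C)nc3nccc2-3)cc1` differs from compound 2 by ethoxy in place of methyl on an aromatic carbon. Among the measured compounds shown here, only one measured step exists, a 2.8-fold lower number from compound 1 to compound 3 (0.45 log units; beyond the scatter), and it concerns a different group on the same ring, so it bears on this change only loosely, showing that a change at that ring can move the number modestly. For compound 4 in this assay the expected step is therefore small, a 1.5-fold lower number from compound 2 to compound 4 (0.18 log units; within the scatter), close to or within the scatter. The estimate for compound 4 is 500000000 nM, with a range from 150000000 nM to 1500000000 nM.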

Compound 4, half-maximal inhibitory concentration: 347000000 nM
Compound 4: middle estimate off by 1.4-fold (0.16 log units), on the high side; measured number inside the range.
By their numbers in this assay, from the lowest: compounds 3, 4, 1 and 2 (each within the scatter of the next, the first and the last beyond it).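

In this assay, the earlier step changed a hydrogen on the ring of compound 1, whereas this one shows that, on the core of compound 2, replacing a methyl at the aromatic carbon para to a large group also matters: a 2.2-fold lower number from compound 2 to compound 4 (0.34 log units; beyond the scatter). The available data give no reason for this step. Because ethoxy differs from methyl in both its oxygen and its carbon count, the compounds shown cannot separate those two features. Methoxy, propoxy or a carboxylic acid at this carbon would help show how far the trend extends.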